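A chlorothiophene sulfonyl in place of a chlorophenyl sulfonyl

A few compounds are considered here, and "the series" means these few. Any claim that something is new, unique, unknown or untested is made for them only; others in the source may bear on it.

Compound 1, `COc1cc2nc(N3CCN(C(=O)c4cccc5ccccc45)CC3)nc(N)c2cc1OC`, gives 59000 nM in a functional assay on PC-3 cells (Homo sapiens) for inhibition; a lower number here means a stronger inhibitor, a higher number a weaker inhibitor.
Compound 2, `COc1cc2nc(N3CCN(C(=O)c4ccc(C(F)(F)F)cc4)CC3)nc(N)c2cc1OC`, reaches only a limit of this assay, > 100000 nM.
Compound 3, `COc1cc2nc(N3CCN(S(=O)(=O)c4ccc(Cl)cc4)CC3)nc(N)c2cc1OC`, gives 23000 nM in this assay.

All three share one core. Compounds 1 and 2 carry their aryl group on a carbonyl carbon; compound 3 carries a 4-chlorophenyl on a sulfonyl sulfur. Going by the values given here, the one step between measured compounds runs within the carbonyl pair: an at least 1.6-fold higher number from compound 1 to compound 2 (0.22 log units; that floor lies within the scatter), and compound 2 sits at the limit of > 100000 nM in this assay, at which 1 of the 3 values shown sits. Among the two numbers shown, compound 3 gives the lower one, and its gap to compound 1 lies beyond the scatter.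

Compound 4, `COc1cc2nc(N3CCN(S(=O)(=O)c4ccc(Cl)s4)CC3)nc(N)c2cc1OC`, differs from compound 3 in one place: 5-chlorothiophen-2-yl in place of 4-chlorophenyl on a sulfonyl sulfur. Among the compounds with values here, no measured step touches the sulfonyl side, so the step from compound 1 to compound 2 gives no direct guide here, and it ends at a limit anyway. The expectation is therefore a step of no clear size beyond the scatter, in either direction: a 1.1-fold higher number from compound 3 to compound 4 (0.04 log units; within the scatter). Compound 4 is estimated at 25000 nM, with a range from 8000 nM to 80000 nM.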

Compound 4, half-maximal inhibitory concentration: 25000 nM
Beside the measured number, compound 4's estimate shows no gap at the digits printed, and the stated range covers the measured number.
By their numbers in this assay, from the lowest: compounds 3 and 4 (each within the scatter of the next); then compound 1. At a limit, above all of these: compound 2.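

On the sulfonyl sulfur, a five-membered aromatic ring with one hetero atom can stand in for a six-membered aromatic ring of carbon only with no change beyond the scatter in this assay: the step is a 1.1-fold higher number from compound 3 to compound 4 (0.04 log units; within the scatter). Until now, compound 3 was the only sulfonyl compound shown, so a single value stood for this position; the pair now shows that, at least for these two chlorine-bearing groups, the number does not depend on which of the two rings is present. Nothing measured here bears on why the two groups read alike.

From the compounds shown here alone, both sulfonyl compounds carry a chlorine, so it remains open how the number would respond if a methoxy group, an amine or a carboxylic acid took the place of that chlorine, or if the ring carried a longer chain. Compounds 1 and 2 also differ from compound 3 in more than one place, so the effect of sulfonyl against carbonyl stays unresolved, and a 4-chlorobenzoyl group on the same ring nitrogen would be the single-change partner for compound 3.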